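The source may report more compounds than this note shows. Statements on the series, on what has been measured and on what is new or still open speak of the compounds shown alone.

The account begins with compound 1 `Cc1nc(S(C)(=O)=O)ccc1Oc1ncnc(OC2CCN(C(=O)OC(C)(C)C(F)(F)F)CC2)c1F`, which in a functional assay on isolated protein for inhibition of Glucose-dependent insulinotropic receptor (Rattus norvegicus), read by HTRF and cAMP accumulation (on this read-out lower numbers stand for an effect already at smaller amounts and higher numbers for an effect only at larger amounts of compound), gives 47.2 nM. Among the three compounds measured, compound 1 stands at the lowest number, yet compound 3 `Cc1nc(S(C)(=O)=O)ccc1Oc1ncnc(OC2CCN(C(=S)OC3(C)CC3)CC2)c1F` gives 48.8 nM, a figure within the scatter of compound 1, whereas compound 2 `Cc1nc(S(C)(=O)=O)ccc1Oc1ncnc(OC2CCN(C(=S)OC(C)C)CC2)c1F` gives 1050 nM. The step of a 1.0-fold higher number from compound 1 to compound 3 (0.01 log units; within the scatter) shows that one replacement on the amine nitrogen in a ring leaves the read-out where it was, while the step of a 22-fold higher number from compound 1 to compound 2 (1.35 log units; beyond the scatter) shows that another replacement at the same place is followed by a large rise. Compound 4 `Cc1nc(S(C)(=O)=O)ccc1Oc1ncnc(OC2CCN(C(=O)C(C)(C)F)CC2)c1F` differs from compound 1 as 1-fluoro-1-methylethyl in place of 1-methyl-1-(trifluoromethyl)ethoxy on a carbonyl carbon. For the measured compounds named here, both earlier steps bear on this change, since both also alter the group carried by the amine nitrogen in a ring; the one that left a group of fewer heavy atoms, with an isopropyl, brought the large rise, and the one that kept a group of more heavy atoms brought none. The entering 1-fluoro-1-methylethyl is again a group of few heavy atoms, so a rise of intermediate size is expected for compound 4, namely a 4.7-fold higher number from compound 1 to compound 4 (0.67 log units; beyond the scatter). Compound 4 is therefore estimated at 220 nM, in a range from 60 nM to 800 nM.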

Compound 4, half-maximal effective concentration: 296 nM
For compound 4 the middle estimate is 1.3-fold (0.13 log units) below the measured one; the measured number falls inside the stated range.
By their numbers in this assay, from the lowest: compounds 1 and 3 (each within the scatter of the next); then compound 4; then compound 2.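

In this assay, the change on the carbonyl carbon gives a 6.3-fold higher number from compound 1 to compound 4 (0.80 log units; beyond the scatter), so an acyl group without the ether oxygen of the leaving group keeps a measurable effect but does not stay level with compound 1. The other two steps place this change in the series, with a 6.1-fold higher number from compound 3 to compound 4 (0.78 log units; beyond the scatter) and a 3.5-fold lower number from compound 2 to compound 4 (0.55 log units; beyond the scatter); the groups on the amine nitrogen in a ring in compounds 2 and 4 have equal heavy-atom counts, so that count alone does not set the number. No measurement available here speaks to the reason for these differences. On these data alone, it remains open how a tert-butyl or a cyclobutyl group on this carbonyl carbon would read. Also open, as far as these compounds go, is what the fluorine of 1-fluoro-1-methylethyl adds, which an isopropyl group at the same place would test.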